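A few compounds are considered here, and "the series" means these few. Any claim that something is new, unique, unknown or untested is made for them only; others in the source may bear on it.

In a functional assay on the whole organism with Rattus norvegicus as the target, with a stated time of 4 h, at a dose of 40 mg/kg by the intraperitoneal route (on this read-out higher numbers stand for more inhibition at the one dose given (going by the name of the read-out) and lower numbers for less inhibition), compound 1 `CC(=O)c1c(C)nc2c(OCc3ccccc3)cccn12` gives 57%. In this assay compound 2 `Cc1nc2c(OCc3ccccc3)cccn2c1CCC#N` gives 40%, and compound 3 `CCSCc1c(C)nc2c(OCc3ccccc3)cccn12` gives 36%. Compound 3 thus holds the lowest of the three numbers, but its gap to compound 2 lies within the scatter, so those two cannot be ordered; only compound 1 stands clearly apart. The measured steps are a number 17 percentage points lower from compound 1 to compound 2 (beyond the scatter) and a number 21 percentage points lower from compound 1 to compound 3 (beyond the scatter), whereas a number 4 percentage points lower from compound 2 to compound 3 (within the scatter). Compound 4 `Cc1nc2c(OCc3ccccc3)cccn2c1CC(=O)O` has not been measured; it differs from compound 3 in that (carboxy in place of ethylsulfanyl on a saturated chain carbon bound to an aromatic carbon). Within the data shown here, only one measured step, a number 4 percentage points lower from compound 2 to compound 3 (within the scatter), touches the same place, and it stayed within the scatter, but it exchanged two groups of which neither is a carboxy, so no measured step speaks directly to this change. Compound 4 is therefore expected to show a number 3 percentage points lower from compound 3 to compound 4 (within the scatter) in this assay, a step no larger than the scatter itself. For compound 4 the estimate is 33%, within 15% to 55%.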

Compound 4, a percentage reported as inhibition, in the whole organism at one dose (the size of the read-out at that dose, not a potency): 12%
Estimate against measurement, compound 4: 21 percentage points above; the whole stated range lies above it.
By their numbers in this assay, from the lowest: compound 4; then compounds 3 and 2 (each within the scatter of the next); then compound 1.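

In this assay, the saturated chain carbon bound to an aromatic carbon now proves sensitive to the group it carries: the earlier exchange there stayed within the scatter, but carboxy in place of ethylsulfanyl gives a number 24 percentage points lower from compound 3 to compound 4 (beyond the scatter) and carboxy in place of cyanomethyl gives a number 28 percentage points lower from compound 2 to compound 4 (beyond the scatter) on the same chain. Carboxymethyl in place of acetyl on an aromatic carbon gives a number 45 percentage points lower from compound 1 to compound 4 (beyond the scatter) and is the only step of this size among the compounds shown. No measurement at hand accounts for these drops.

The compounds shown leave open whether a methyl ester or a primary amide of the carboxylic acid would read like compound 4 or like compound 3. They also leave open how an amine or a longer chain ending in carboxy would read at this place.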